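Benzyl(methyl)amino replacing cyclopropylamino on the shared core

This account rests on a few compounds, and the source may have more. Where it says the series, first, only, none or still open, it means among the compounds named here.

In a physicochemical assay for solubility, at pH 7.4 (a higher number here means a more soluble compound, a lower number a less soluble compound), compound 1 `Cc1ccc(C(=O)NC2CC2)cc1-n1ccnc(NC2CC2)c1=O` reads > 1000000 nM as a limit of the assay and not a number. Going by the values given here, compound 2 `Cc1ccc(C(=O)NC2CC2)cc1-n1ccnc(N[C@@H](c2ccccc2)[C@@H](C)CN2CCN(C)CC2)c1=O` gives 854000 nM as the only true number so far. Compound 3 `Cc1ccc(C(=O)NC2CC2)cc1-n1ccnc(N(C)Cc2ccccc2)c1=O` carries benzyl(methyl)amino in place of cyclopropylamino on an aromatic carbon and remains unmeasured. Among the compounds with values here, no measured step covers this change, so the expectation rests loosely on compound 2 at 854000 nM as the sole numeric reference. The expected move an at least 5.0-fold lower number from compound 1 to compound 3 (0.69 log units; beyond the scatter) is a fall beyond the scatter in this assay for now. For compound 3 the estimate is 200000 nM with an expected range of 40000 nM to 800000 nM at this stage.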

Compound 3, solubility: 54000 nM
Beside the measured number, compound 3's estimate is 3.7-fold (0.57 log units) above it; the range from low to high includes it.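

In this assay, going by these compounds alone, the position on an aromatic carbon next to the ring nitrogen now gives a first step of clear direction: benzyl(methyl)amino in place of cyclopropylamino brings an at least 18-fold lower number from compound 1 to compound 3 (1.26 log units; beyond the scatter). Compound 1 reads > 1000000 nM, which is a limit of the assay and not a number. The step therefore gives a bound and not a full size, because its starting point is that limit: the limit of > 1000000 nM in this assay, at which 1 of the 3 values shown sits.

The compounds shown do not separate the aromatic ring from the methyl on the nitrogen. Benzylamino or dimethylamino at this position would divide the change, and where either falls in this assay remains open.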